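The source may hold more compounds than are shown below. What is called first, only, known or untested is meant among the compounds shown, and "the series" means these compounds.

Series notes. All four compounds share one core and differ only in the group carried on a nitrogen on an aromatic ring and in a single bromo substituent. Compound 1 `Clc1cccc(Nc2ncnc3ccc(NCc4cccs4)cc23)c1` carries the (thiophen-2-yl)methyl group; in a functional assay on A549 cells (Homo sapiens) for antiproliferative activity, read by MTT assay, with a stated time of 48 h (on this read-out higher numbers stand for weaker inhibition and lower numbers for stronger inhibition), compound 1 gives 2080 nM. Compound 2 `Clc1cccc(Nc2ncnc3ccc(NCc4ccc(Br)s4)cc23)c1` differs from compound 1 by bromo in place of hydrogen on an aromatic carbon; in this assay compound 2 gives 820 nM, and the step is a 2.5-fold lower number from compound 1 to compound 2 (0.40 log units; beyond the scatter). Compound 3 `O=C(/C=C/c1cccs1)Nc1ccc2ncnc(Nc3cccc(Cl)c3)c2c1` has the other core, differing from compound 1 by (2-(thiophen-2-yl)ethenyl)carbonyl in place of (thiophen-2-yl)methyl on a nitrogen on an aromatic ring. In this assay compound 3 gives 9310 nM, the highest number of the three measured; the step is a 4.5-fold higher number from compound 1 to compound 3 (0.65 log units; beyond the scatter), and from the brominated analogue it is an 11-fold higher number from compound 2 to compound 3 (1.06 log units; beyond the scatter).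

Compound 4 `O=C(/C=C/c1ccc(Br)s1)Nc1ccc2ncnc(Nc3cccc(Cl)c3)c2c1` is not yet measured. It differs from compound 3 by bromo in place of hydrogen on an aromatic carbon. This is the same change as that between compound 1 and compound 2, and the place is described in the same words for both pairs, so it is taken as the same change on the second core. Within the data shown here, only one measured instance of it exists, so whether it carries over is not known. Using the step from compound 1 to compound 2 as the guide, the step from compound 3 to compound 4 in this assay is expected to be about a 2.5-fold lower number from compound 3 to compound 4 (0.39 log units; beyond the scatter). Compound 4 is therefore estimated at 3800 nM in this assay, with a range from 1500 nM to 9500 nM expected, because compound 3 stands at 9310 nM. Among the measured compounds shown here, the single precedent, a 2.5-fold lower number from compound 1 to compound 2 (0.40 log units; beyond the scatter), is the only support for this.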

Compound 4, half-maximal inhibitory concentration: 1580 nM
Beside the measured number, compound 4's estimate is 2.4-fold (0.38 log units) above it; the range from low to high includes it.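

In this assay, bromo in place of hydrogen on the thiophen-2-yl group again gives a lower number on the second core, a 5.9-fold lower number from compound 3 to compound 4 (0.77 log units; beyond the scatter), and the two steps cannot be told apart in size: the same change on two cores in this assay, a 2.5-fold lower number (0.40 log units; beyond the scatter) from compound 1 to compound 2 and a 5.9-fold lower number (0.77 log units; beyond the scatter) from compound 3 to compound 4, 2.3-fold (0.37 log units) apart, within the scatter of two such steps. Within this series, then, the change carries from the core of compound 1 to the core of compound 3, in direction and, within the scatter, in size, although the two cores differ in the link that joins the thiophene to the nitrogen on the aromatic ring. Among these compounds, this rests on only two matched pairs, with one substituent at one place and one cell read-out, so it does not show that the step would hold on any further core, and it gives no reason for the lower numbers.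

Still open, on these data alone, is whether chloro, methyl or methoxy at the place bromo occupies would give a step of similar size, and whether an amine or a carboxylic acid there would follow the same direction. Also open, as far as these compounds go, is whether the step would survive on a core with a longer chain between the thiophene and the nitrogen, or with phenyl in place of the thiophene.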